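The source may report more compounds than this note shows. Statements on the series, on what has been measured and on what is new or still open speak of the compounds shown alone.

In a functional assay on cells (T-cell line, Homo sapiens) for inhibition (a lower number here means a stronger inhibitor, a higher number a weaker inhibitor), compound 1 (`Clc1ccccc1CCCN1CCC(COC(c2ccccc2)c2ccccc2)CC1`) gives 800 nM and compound 2 (`CCCCN1CCC(COC(c2ccccc2)c2ccccc2)CC1`) gives 14000 nM while compound 3 (`CCCCCCN1CCC(COC(c2ccccc2)c2ccccc2)CC1`) gives 5500 nM as the second highest of the three numbers. Compound 4 (`CCCCCCCCCN1CCC(COC(c2ccccc2)c2ccccc2)CC1`) departs from compound 3 by propyl in place of hydrogen on a saturated chain carbon, six bonds along the chain from an amine nitrogen in a ring with the change sited on a saturated chain carbon, six bonds along the chain from an amine nitrogen in a ring. Within the data shown here, the closest precedent is the one chain extension measured, a 2.5-fold lower number from compound 2 to compound 3 (0.41 log units; beyond the scatter) and modest in size. The steps replacing 2-chlorophenyl, an 18-fold higher number from compound 1 to compound 2 (1.24 log units; beyond the scatter) and a 6.9-fold higher number from compound 1 to compound 3 (0.84 log units; beyond the scatter) bear less directly. A modest step to a lower number is therefore expected in this assay although a single precedent cannot show that the trend continues. The estimated step is a 2.8-fold lower number from compound 3 to compound 4 (0.44 log units; beyond the scatter) as a working expectation. The expected value for compound 4 is 2000 nM (estimated range 700 nM to 6000 nM).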

Compound 4, half-maximal inhibitory concentration: 700 nM
Compound 4: the middle estimate sits 2.9-fold (0.46 log units) above what was measured; the measured number falls inside the stated range.
By their numbers in this assay, from the lowest: compounds 4 and 1 (each within the scatter of the next); then compound 3; then compound 2.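

In this assay the number keeps falling as the chain on the amine nitrogen in a ring grows beyond that of compound 3, with a 7.9-fold lower number from compound 3 to compound 4 (0.90 log units; beyond the scatter) and a 20-fold lower number from compound 2 to compound 4 (1.30 log units; beyond the scatter) over the three straight chains. Chain length alone also matches the 2-chlorophenyl compound: a 1.1-fold lower number from compound 1 to compound 4 (0.06 log units; within the scatter) places hexyl in place of 2-chlorophenyl within the scatter, so 2-chlorophenyl is not required for this level of inhibition.

From the compounds shown here alone, whether a longer chain continues the trend, and whether an amine or a carboxylic acid at the chain end is tolerated, stays open. Nothing available accounts for the chain-length trend.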